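This account rests on a few compounds, and the source may have more. Where it says the series, first, only, none or still open, it means among the compounds named here.

Compound 1 `N#C/C(=C\c1ccco1)C(=O)NCc1ccc(Cl)c(Cl)c1` and compound 2 `N#C/C(=C\c1ccc(Cl)cc1)C(=O)NCc1ccc(Cl)c(Cl)c1` share a core carrying a nitrile and an amide, and differ only in the ring attached to the double-bonded chain carbon. In a functional assay on HT-29 cells (Homo sapiens) for inhibition, read by MTT assay, with a stated time of 72 h (a higher number here means a weaker inhibitor of growth, a lower number a stronger inhibitor of growth), compound 1 gives 20000 nM, and compound 2 gives 33000 nM. Among the two measured numbers compound 2 stands highest, with compound 1 nearest and within the scatter of it, as the step of a 1.7-fold higher number from compound 1 to compound 2 (0.22 log units; within the scatter) shows. Compound 3 `COc1ccc(/C=C(\C#N)C(=O)NCc2ccc(Cl)c(Cl)c2)cc1` differs from compound 2 by methoxy in place of chloro on an aromatic carbon. Within the data shown here, the step of a 1.7-fold higher number from compound 1 to compound 2 (0.22 log units; within the scatter) is the only measured step that touches this ring, and it stayed within the scatter, so a further change on the same ring is expected to give no step beyond the scatter in this assay; the expected step is a 1.1-fold lower number from compound 2 to compound 3 (0.04 log units; within the scatter). Compound 3 is therefore estimated at 30000 nM, with a range from 10000 nM to 90000 nM.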

Compound 3, concentration for 50% growth inhibition: > 100000 nM
Compound 3: only a limit was reported; the forecaster's own chance of this, stated with the estimate: 15%; middle value at least 3.3-fold (0.52 log units) from the limit.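

The ring on the double-bonded chain carbon is less indifferent than compounds 1 and 2 alone suggested: in this assay, methoxy in place of chloro on this aromatic carbon, para to a large group, gives an at least 3.0-fold higher number from compound 2 to compound 3 (0.48 log units; beyond the scatter). Likewise, 4-methoxyphenyl in place of furan-2-yl gives an at least 5.0-fold higher number from compound 1 to compound 3 (0.69 log units; beyond the scatter), so the 4-methoxyphenyl compound separates from both neighbours, while those two remain within the scatter of each other. Compound 3 has only a limit of the assay rather than a number, so the full size of both steps stays unknown: the limit of > 100000 nM in this assay, at which 1 of the 3 values shown sits.

The compounds shown leave open whether this loss belongs to methoxy in particular or would also appear with another group on this carbon, such as an amine, a hydroxy group or a longer ethoxy chain. They also leave open why the change has this effect.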